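Adding a Ring Nitrogen to a Serotonin Receptor Ligand

The source may report more compounds than this note shows. Statements on the series, on what has been measured and on what is new or still open speak of the compounds shown alone.

Of the compounds shown here, two sharing one core have been measured so far. Compound 1 `O=c1n(CCCCCCN2CCN(c3cccc(Cl)c3Cl)CC2)nc2ccccn12` carries a 2,3-dichlorophenyl group on the amine nitrogen in the ring; in an assay on HEK293 cells for displacement of a labelled ligand from 5-hydroxytryptamine receptor 6 (Homo sapiens), read by radioligand binding (a higher number here means a weaker inhibitor, a lower number a stronger inhibitor), compound 1 gives 299 nM. Compound 2 `O=c1n(CCCCCCN2CCN(c3cccc4ccccc34)CC2)nc2ccccn12` carries a naphthalen-1-yl group in the same place, and in this assay compound 2 gives 285 nM. The step of a 1.0-fold lower number from compound 1 to compound 2 (0.02 log units; within the scatter) shows that swapping these two groups hardly moved the number. Of the two numbers shown, that of compound 2 is the smaller, but the gap to compound 1 lies within the scatter, so neither compound can be called the stronger inhibitor.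

Compound 3 `O=c1n(CCCCCCN2CCN(c3cccc4cccnc34)CC2)nc2ccccn12` is not yet measured. It differs from compound 2 in one place: quinolin-8-yl in place of naphthalen-1-yl on an amine nitrogen in a ring. Going by the values given here, no measured step covers this particular exchange; the only step measured, a 1.0-fold lower number from compound 1 to compound 2 (0.02 log units; within the scatter), concerns a different pair of groups and was itself within the scatter. On this basis a step of no size beyond the scatter is expected, and the expected step of a 1.1-fold lower number from compound 2 to compound 3 (0.06 log units; within the scatter) reflects that. Compound 3 is therefore estimated at 250 nM in this assay, with a range from 80 nM to 800 nM.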

Compound 3, inhibition constant: 4140 nM
Beside the measured number, compound 3's estimate is 17-fold (1.22 log units) below it, outside the stated range (above it).
By their numbers in this assay, from the lowest: compounds 2 and 1 (each within the scatter of the next); then compound 3.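

At this place, on an amine nitrogen in a ring, compounds 1 and 2 had suggested that the group could be exchanged with little consequence, but the result shows otherwise: in this assay a change that keeps the count of heavy atoms and swaps one ring carbon for a nitrogen, adding a hydrogen-bond acceptor, gives a 15-fold higher number from compound 2 to compound 3 (1.16 log units; beyond the scatter) and makes compound 3 clearly the weakest inhibitor of the three. The comparison with the 2,3-dichlorophenyl group, a 14-fold higher number from compound 1 to compound 3 (1.14 log units; beyond the scatter) in the same assay, is of similar size, so quinolin-8-yl stands apart from both other groups, which themselves remain within the scatter of each other. The data at hand offer no independent measurement that would explain why this single atom exchange matters so much.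

Going by these compounds, it remains open whether the loss belongs to quinolin-8-yl alone or would also appear with quinolin-5-yl, which carries its ring nitrogen elsewhere. The compounds shown also leave open how a methoxy group on a phenyl ring at this place, or a shorter chain on the shared core, would behave.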